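Swapping a Chlorophenyl Ring for Pyridin-4-yl

The compounds below may be only part of what the source reports. "The series", "measured", "known", "first", "only" and "open" are said of these compounds alone.

Measured so far:
compound 1, `O=C(N/N=C/c1ccc(F)cc1)c1cccnc1Nc1cccc(C(F)(F)F)c1`: 33.9%
compound 2, `O=C(N/N=C/c1ccc(Cl)cc1)c1cccnc1Nc1cccc(C(F)(F)F)c1`: 52.4%

Two hydrazones built on the same core have been tested in a functional assay on the whole organism (strain Wistar) for inhibition, with Rattus norvegicus as the target, read by paw edema, with a stated time of 30 min, at a dose of 10 mg/kg by the intraperitoneal route; on this read-out higher numbers stand for more inhibition at the one dose given (going by the name of the read-out) and lower numbers for less inhibition. Compound 1 gives 33.9% in this assay, while compound 2 gives 52.4%. Going by the values given here, the single step between them is a number 18.5 percentage points higher from compound 1 to compound 2 (beyond the scatter), which places compound 2 as the higher of the two numbers, with compound 1 as its only neighbour.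

Compound 3, `O=C(N/N=C/c1ccncc1)c1cccnc1Nc1cccc(C(F)(F)F)c1`, is not yet measured. It differs from compound 2 in that (pyridin-4-yl in place of 4-chlorophenyl on a carbon with a double bond to nitrogen). Among the compounds with values here, no measured step touches this change directly: the only step in hand exchanges one halogen for another on the same ring, whereas here the whole halogenated ring gives way to a heteroaromatic one. That step was modest, and it gives no direction for a change of this kind. With nothing to anchor a shift either way, compound 3 is expected to land between the two measured values, with wide uncertainty, at 42% with a range of 22% to 62%. The step this estimate implies is a number 10.4 percentage points lower from compound 2 to compound 3 (beyond the scatter), expected to be of a size comparable to the scatter rather than clearly beyond it.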

Compound 3, a percentage reported as inhibition, in the whole organism at one dose (the size of the read-out at that dose, not a potency): 68.1%
For compound 3 the middle estimate is 26.1 percentage points below the measured one; measured number outside the range, above it.
By their numbers in this assay, from the lowest: compound 1; then compound 2; then compound 3.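

In this assay the place on the carbon with a double bond to nitrogen turned out to accept more than an exchange of one halogen for another: pyridin-4-yl in place of 4-chlorophenyl gave a number 15.7 percentage points higher from compound 2 to compound 3 (beyond the scatter), so among these three compounds the highest number belongs to a ring with no halogen and with a hetero atom. Set against the 4-fluorophenyl ring, the same pyridin-4-yl ring gave a number 34.2 percentage points higher from compound 1 to compound 3 (beyond the scatter), and with both steps beyond the scatter, compound 3 stands clearly above the other two on this read-out. Nothing available explains why the pyridin-4-yl ring gives the higher number.

The three compounds do not separate the presence of the ring nitrogen from the absence of the halogen, a question that an unsubstituted phenyl ring or a pyridin-3-yl ring at this place would address. As far as these compounds go, it also remains open how this place would respond to a phenyl ring carrying an amine or a carboxylic acid, and the single dose gives no measure of potency for any of the compounds.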